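Aryl for allyl on the ring nitrogen of the shared core

The compounds below may be only part of what the source reports. "The series", "measured", "known", "first", "only" and "open" are said of these compounds alone.

Measured so far in an assay for inhibition of acid-sensing ion channel 3 (Homo sapiens), read by patch clamp, tested at 1 uM; on this read-out higher numbers stand for more inhibition at the one concentration tested (going by the name of the read-out) and lower numbers for less inhibition:
- compound 1, `NC(N)=NC(=O)c1nc(Cl)c(NCc2ccccc2Cl)nc1N`: 31%
- compound 2, `C=CCNc1nc(N)c(C(=O)N=C(N)N)nc1Cl`: 16%
- compound 3, `NC(N)=NC(=O)c1nc(Cl)c(NCc2cccc(F)c2)nc1N`: 29%

Compound 2 stands lowest of the three numbers. Its nearest neighbour is compound 3, with a number 13 percentage points higher from compound 2 to compound 3 (beyond the scatter); its furthest is compound 1, reached by a number 15 percentage points lower from compound 1 to compound 2 (beyond the scatter) read in reverse. Compound 1 and compound 3 sit within the scatter of each other, a number 2 percentage points lower from compound 1 to compound 3 (within the scatter).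

Compound 4, `NC(N)=NC(=O)c1nc(Cl)c(Nc2cccc(Cl)c2)nc1N`, is not yet measured. It differs from compound 2 as follows: 3-chlorophenyl in place of allyl on a nitrogen on an aromatic ring. The change is of the same kind as the two steps that bear on it, an aromatic ring entering where the short unsaturated chain stood, and in both of those steps the number is higher on the side with the ring, by a modest step: a number 13 percentage points higher from compound 2 to compound 3 (beyond the scatter) and, in the opposite direction, a number 15 percentage points lower from compound 1 to compound 2 (beyond the scatter). Within the data shown here, compound 4 carries the ring directly on the nitrogen, with no saturated chain carbon between, and no measured pair covers that point, so the expectation rests on the ring-for-chain steps alone.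

Compound 4 is therefore expected to rise above compound 2 by a modest step, a number 12 percentage points higher from compound 2 to compound 4 (beyond the scatter), and its expected value in this assay is 28%, with a range from 10% to 45%.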

Compound 4, a percentage reported as inhibition, at one concentration (the size of the read-out at that concentration, not a potency): 47%
Estimate against measurement, compound 4: 19 percentage points below; measured number outside the range, above it.
By their numbers in this assay, from the lowest: compound 2; then compounds 3 and 1 (each within the scatter of the next); then compound 4.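

Notes on the nitrogen on the aromatic ring: in this assay, 3-chlorophenyl in place of allyl gives a number 31 percentage points higher from compound 2 to compound 4 (beyond the scatter), a large step, whereas the two earlier ring-for-chain steps, both with a saturated chain carbon in the link, were modest. This position therefore accepts an aromatic ring bound directly to the nitrogen, and the ring-bearing compounds do not all sit at one level: compound 1 reads 31% and compound 3 reads 29%, while compound 4 reads 47%. Nothing on hand accounts for the size of this step.

Compound 4 differs from compounds 1 and 3 in both the link to the ring and the substitution on the ring, so the share of each in the higher number remains unresolved; an unsubstituted phenyl directly on the nitrogen, or 3-chlorophenyl on a saturated chain carbon, would separate the two. Also open, on these data alone, is how a saturated ring such as cyclohexyl, or a longer chain, would read at this nitrogen.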